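Adding a Butylcarbonyl Ester to an Inactive Core

The source may hold more compounds than are shown below. What is called first, only, known or untested is meant among the compounds shown, and "the series" means these compounds.

Measured compounds in a functional assay on HeLa cells (Homo sapiens) for inhibition, read by MTT assay, with a stated time of 24 h; on this read-out higher numbers stand for weaker inhibition and lower numbers for stronger inhibition:
Compound 1 `C/C=C(\C)C(=O)O[C@H]1[C@]2(C)C[C@@H]3O[C@@]1(O)C=C1C4=CC(=O)O[C@@H](c5ccoc5)[C@]4(C)CC[C@@H]1[C@]3(C)[C@@H]2[C@@H](O)C(=O)OC` gives > 100000 nM, a limit of the assay.
Compound 2 `CCOC(=O)[C@H](O)[C@@H]1[C@@]2(C)C[C@@H]3O[C@@](O)(C=C4C5=CC(=O)O[C@@H](c6ccoc6)[C@]5(C)CC[C@@H]4[C@@]31C)[C@H]2O` gives > 100000 nM, also a limit.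
Compound 3 `C/C=C(\C)C(=O)O[C@H]1[C@]2(C)C[C@@H]3O[C@@]1(O)C=C1C4=CC(=O)O[C@@H](c5ccoc5)[C@]4(C)CC[C@@H]1[C@]3(C)[C@@H]2C(=O)C(=O)OC` gives > 100000 nM, again a limit.

Compound 1 therefore has no number of its own, only a limit, and the two other compounds share the same limit, so none of the three can be placed above or below another. Among the compounds with values here, the one single-point change among them, the step that the two limits leave unreadable from compound 1 to compound 3, cannot be read for the same reason: both ends sit at the limit. What the set shows is summed up in the limit of > 100000 nM in this assay, at which 3 of the 3 values shown sit.

Compound 4 `C/C=C(\C)C(=O)O[C@@H]1[C@]2(OC(=O)CCCC)C=C3C4=CC(=O)O[C@@H](c5ccoc5)[C@]4(C)CC[C@@H]3[C@@]3(C)[C@H](C[C@]1(C)[C@H]3[C@@H](O)C(=O)OC)O2` differs from compound 1 by butylcarbonyl in place of hydrogen on an oxygen on a saturated carbon. Within the data shown here, no measured step touches this position, so the only guide is that every measured compound on this shared core sits at the limit. With no evidence of any change producing a readable number, no movement beyond the scatter is expected, and the most likely outcome is that compound 4 also reaches the limit. Compound 4 is therefore estimated at 150000 nM, within 30000 nM to 600000 nM, which means the expected step that the limit leaves unreadable from compound 1 to compound 4 is essentially none.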

Compound 4, half-maximal inhibitory concentration: > 100000 nM
Compound 4: no number, only a limit; the forecaster's own chance of this, stated with the estimate: 85%; the middle value does not contradict the limit.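

In this assay compound 4 gives > 100000 nM, which is a limit and not a number. Compound 1 also has only a limit, so no new step can be read from the change of hydroxy to (butylcarbonyl)oxy. The compounds shown leave open whether any change to the shared core gives a readable number: the limit of > 100000 nM in this assay, at which 4 of the 4 values shown sit.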